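The compounds below may be only part of what the source reports. "The series", "measured", "known", "first", "only" and "open" are said of these compounds alone.

Measured so far in a functional assay, with a stated time of 150 min, tested at 10 ug/mL; a higher number here means a stronger effect of the compound at the concentration tested, a lower number a weaker effect:

- compound 1, `COc1ccc(C(=O)c2sc(Nc3ccc(Cl)cc3)c(C(=O)O)c2C)cc1`: "not active" (no number reported)
- compound 2, `Cc1ccc(C(=O)c2sc(Nc3ccccc3)c(C(=O)O)c2C)cc1`: 0.85%
- compound 3, `Cc1ccc(C(=O)c2sc(Nc3ccc(F)cc3)c(C(=O)O)c2C)cc1`: "not active" (no number reported)

Compound 3 has no single number in this assay; its entry reads only as "not active" (no number reported), and compound 1 stands the same way with "not active" (no number reported). Among the compounds with values here, the one numeric value in the set belongs to compound 2, which gives 0.85% in this assay, a read-out that itself sits low. Taken together, none of the three measured compounds shows an effect of note at the tested concentration, and nothing in the data separates them from one another.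

Compound 4, `Cc1ccc(C(=O)c2sc(Nc3ccc(Cl)cc3)c(C(=O)O)c2C)cc1`, is the next compound to be measured in this assay. It differs from compound 3 by chloro in place of fluoro on an aromatic carbon. Within the data shown here, no step between two measured compounds covers this change, so there is no measured size to lean on. Given that compound 3 reports "not active" (no number reported) and compound 1, which already carries the chloro group on the same aryl amine, also reports "not active" (no number reported), the expectation is a step of no size beyond the scatter, with compound 4 staying at the low end of the read-out.

Compound 4 is therefore expected to give about 1% in this assay, within a range from 0% to 6%, and quite possibly to be reported without a number at all.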

Compound 4, a percentage reported as activity, at one concentration (the size of the read-out at that concentration, not a potency): "not active" (no number reported)
No number was reported for compound 4, and the estimate cannot be compared.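

In this assay, within the data shown here, compound 3 reads "not active" (no number reported) and compound 4 reads "not active" (no number reported) so no step between them can be read. The compounds shown leave open how far fluoro or chloro at this place on the aryl amine shifts the read-out. Nothing measured here offers an explanation for this result.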